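A few compounds are considered here, and "the series" means these few. Any claim that something is new, unique, unknown or untested is made for them only; others in the source may bear on it.

Working notes on the series.

Compound 1 `COc1ccc(-c2nn(-c3ccccc3)cc2C(=O)NOCc2ccccc2)cc1` is the parent; in an ADME assay on HEK-293T cells (Homo sapiens) for antiproliferative activity, read by MTT assay, with a stated time of 48 h, in the presence of a further agent that is not named here (a higher number here means that more compound is tolerated, a lower number that less compound is tolerated), compound 1 gives 201000 nM. Compound 2 `COc1ccc(-c2nn(-c3ccccc3)cc2C(=O)NOCc2ccccc2F)cc1` carries one change, (fluoro in place of hydrogen on an aromatic carbon), and in this assay compound 2 gives 24600 nM, a step of an 8.2-fold lower number from compound 1 to compound 2 (0.91 log units; beyond the scatter). Compound 3 `O=C(NOCc1ccccc1)c1cn(-c2ccccc2)nc1-c1ccc(Cl)cc1` differs from compound 1 in the core by chloro in place of methoxy on an aromatic carbon; in this assay compound 3 gives 51900 nM, a step of a 3.9-fold lower number from compound 1 to compound 3 (0.59 log units; beyond the scatter).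

Compound 4 `O=C(NOCc1ccccc1F)c1cn(-c2ccccc2)nc1-c1ccc(Cl)cc1` is not yet measured. Within the data shown here, it differs from compound 3 by fluoro in place of hydrogen on an aromatic carbon, the same change as between compound 1 and compound 2 and at the same place, with the measured step of an 8.2-fold lower number from compound 1 to compound 2 (0.91 log units; beyond the scatter) as the only precedent. On that one precedent, the step from compound 3 to compound 4 is expected to be of similar size, a 7.4-fold lower number from compound 3 to compound 4 (0.87 log units; beyond the scatter), because compound 1 to compound 2 gave an 8.2-fold lower number from compound 1 to compound 2 (0.91 log units; beyond the scatter) on the other core. Whether the altered core of compound 3 carries the change in the same way is not known from the data. Compound 4 is therefore estimated at 7000 nM, within 2500 nM to 20000 nM.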

Compound 4, half-maximal cytotoxic concentration: 126000 nM
Beside the measured number, compound 4's estimate is 18-fold (1.26 log units) below it; measured number above the stated range.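

In this assay the fluoro change gives a 2.4-fold higher number from compound 3 to compound 4 (0.39 log units; beyond the scatter), the reverse in direction of its step on the core of compound 1: the same change on two cores in this assay, an 8.2-fold lower number (0.91 log units; beyond the scatter) from compound 1 to compound 2 and a 2.4-fold higher number (0.39 log units; beyond the scatter) from compound 3 to compound 4, 20-fold (1.30 log units) apart, beyond the scatter of two such steps. Read the other way, chloro in place of methoxy gives a 5.1-fold higher number from compound 2 to compound 4 (0.71 log units; beyond the scatter) when the 2-fluorobenzyl group is present, again the reverse of its step with benzyl: the same change on two cores in this assay, a 3.9-fold lower number (0.59 log units; beyond the scatter) from compound 1 to compound 3 and a 5.1-fold higher number (0.71 log units; beyond the scatter) from compound 2 to compound 4, 20-fold (1.30 log units) apart, beyond the scatter of two such steps. In these four compounds, then, the two changes do not add, and the step measured on one core does not carry to the other, though this rests on a single set of four compounds and shows nothing about why the direction reverses.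

The compounds shown leave open whether a chloro or a methyl group on the same aromatic carbon would reverse in the same way between the two cores. They also leave open which direction an amine or a carboxylic acid on the benzyl group would take on the core of compound 1 and on the core of compound 3.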